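A few compounds are considered here, and "the series" means these few. Any claim that something is new, unique, unknown or untested is made for them only; others in the source may bear on it.

Compound 2 `O=C(Nc1ccc(Br)cc1)c1c(NCCO)cc(-c2ccc(Br)cc2)oc1=O`: > 20000 nM
Compound 1 `COc1ccccc1NC(=O)c1c(NCCO)cc(-c2cccc(Br)c2)oc1=O`: > 20000 nM

In an ADME assay on Huh-7 cells (Homo sapiens) for cytotoxicity, with a stated time of 3 days (on this read-out lower numbers stand for higher toxicity in this test and higher numbers for lower toxicity in this test), compound 2 gives > 20000 nM, which is a limit of the assay rather than a number. Compound 1 likewise reaches only a limit, > 20000 nM. Both values sit at the limit of > 20000 nM in this assay, at which 2 of the 2 values shown sit. Compound 3 `COc1ccccc1NC(=O)c1c(NCCO)cc(-c2ccc(Br)cc2)oc1=O` differs from compound 2 by 2-methoxyphenyl in place of 4-bromophenyl on an amide-type nitrogen. Compound 1 already carries 2-methoxyphenyl on the amide nitrogen and is not toxic up to the limit, so no step beyond the scatter is expected in this assay. The estimate for compound 3 is 25000 nM, from 10000 nM to 60000 nM, which means the expected step that the limit leaves unreadable from compound 2 to compound 3.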

Compound 3, half-maximal cytotoxic concentration: > 20000 nM
Compound 3: no number, only a limit (the forecaster's own chance of this, stated with the estimate: 85%); the middle value lies beyond the limit too.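

Compound 3 also reaches only a limit, so no step between it and compound 1 or compound 2 can be read: the limit of > 20000 nM in this assay, at which 3 of the 3 values shown sit.

The compounds shown leave open where each true value lies beyond that limit, and whether either change affects cytotoxicity at all.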